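Aryl swap on the shared core: methyl to methoxy

The compounds below may be only part of what the source reports. "The series", "measured", "known", "first", "only" and "open" are said of these compounds alone.

Compound 1 `Fc1ccccc1Nc1nc2nonc2nc1NCCC(F)(F)F` carries a 3,3,3-trifluoropropyl group on a nitrogen on the aromatic core. In an assay on mitochondria from L6 cells (Rattus norvegicus) for activation, with a stated time of 90 min (on this read-out lower numbers stand for an effect already at smaller amounts and higher numbers for an effect only at larger amounts of compound), compound 1 reaches only the limit > 100000 nM, so no number is known for it. Going by the values given here, compound 2 `Cc1ccccc1Nc1nc2nonc2nc1Nc1ccccc1F` is the 2-methylphenyl analogue and in this assay gives 1100 nM, the only number so far. Among the compounds with values here, the step of an at least 90-fold lower number from compound 1 to compound 2 (1.95 log units; beyond the scatter) is the single measured step, and it concerns a change from a fluorinated chain to an aryl group at the same nitrogen.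

Compound 3 `COc1cccc(Nc2nc3nonc3nc2Nc2ccccc2F)c1` differs from compound 2 by 3-methoxyphenyl in place of 2-methylphenyl on a nitrogen on an aromatic ring. Within the data shown here, the one measured step does not speak to an aryl-to-aryl exchange, so no shift beyond the scatter is expected; the estimate for the step is a 1.4-fold higher number from compound 2 to compound 3 (0.13 log units; within the scatter). Compound 3 is therefore expected at about 1500 nM, within the range 400 nM to 6000 nM.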

Compound 3, half-maximal effective concentration: 830 nM
Compound 3: middle estimate off by 1.8-fold (0.26 log units), on the high side; the measured number falls inside the stated range.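

Working notes: in this assay, the aryl-to-aryl exchange at this nitrogen gives a 1.3-fold lower number from compound 2 to compound 3 (0.12 log units; within the scatter), so 3-methoxyphenyl and 2-methylphenyl are not told apart here, although the entering group carries an oxygen and a hydrogen-bond acceptor that the leaving group lacks. The gap to the 3,3,3-trifluoropropyl group of compound 1 now appears with a second aryl group, as an at least 120-fold lower number from compound 1 to compound 3 (2.08 log units; beyond the scatter), so it no longer rests on 2-methylphenyl alone. The true size of that step stays unknown because compound 1 sits at a limit of the assay: the limit of > 100000 nM in this assay, at which 1 of the 3 values shown sits.

Still open, from the compounds shown here alone, is whether a non-fluorinated chain such as butyl, or a saturated ring such as cyclohexyl, would give a measurable number at this nitrogen. Also open, going by these compounds, is how a phenyl ring bearing an amine or a carboxylic acid would read.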